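Benzyl gives way to ethoxycarbonyl in compound 4

The compounds below may be only part of what the source reports. "The series", "measured", "known", "first", "only" and "open" are said of these compounds alone.

- Compound 1 `Cc1cn([C@@H]2O[C@H](CO[Si](C)(C)C(C)(C)C(C)C)[C@@]3(OS(=O)(=O)C=C3NC(=O)NC(=O)c3ccccc3)[C@H]2O[Si](C)(C)C(C)(C)C)c(=O)n(C)c1=O`: > 50000 nM (a limit of the assay)
- Compound 2 `Cc1cn([C@@H]2O[C@H](COCc3ccccc3)[C@@]3(OS(=O)(=O)C=C3NC(=O)NC(=O)c3ccccc3)[C@H]2O[Si](C)(C)C(C)(C)C)c(=O)n(C)c1=O`: > 50000 nM (a limit of the assay)
- Compound 3 `Cc1cn([C@@H]2O[C@H](CO[Si](C)(C)C(C)(C)C)[C@@]3(OS(=O)(=O)C=C3NC(=O)NCc3ccccc3)[C@H]2O[Si](C)(C)C(C)(C)C)c(=O)n(C)c1=O`: 4100 nM

Among the measured compounds shown here, in an ADME assay on HEL cells (Homo sapiens) for cytotoxicity, with a stated time of 3 days (on this read-out lower numbers stand for higher toxicity in this test and higher numbers for lower toxicity in this test), compound 3 gives 4100 nM as the only true number of the three. Compound 1 gives > 50000 nM as a limit and not a number. Compound 2 likewise gives > 50000 nM as a limit and not a number. Both stand at the limit of > 50000 nM in this assay, at which 2 of the 3 values shown sit, and so offer no exact value to compare with compound 3.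

The change to compound 4 `CCOC(=O)NC(=O)NC1=CS(=O)(=O)O[C@@]12[C@@H](CO[Si](C)(C)C(C)(C)C)O[C@@H](n1cc(C)c(=O)n(C)c1=O)[C@@H]2O[Si](C)(C)C(C)(C)C` is ethoxycarbonyl in place of benzyl on an amide-type nitrogen and nothing else. For the measured compounds named here, no measured step covers this change. Going by the values given here, the one step available is a step that the two limits leave unreadable from compound 1 to compound 2 and it lies elsewhere in the structure, so it gives no size to carry over. Compound 4 will carry a carbonyl on the amide-type nitrogen, as compound 1 does with its limit of > 50000 nM in this assay, so a shift toward lower toxicity is expected. The expected move is a 3.7-fold higher number from compound 3 to compound 4 (0.56 log units; beyond the scatter) and it remains uncertain. For compound 4 the estimated value is 15000 nM with an expected range of 4000 nM to 50000 nM on this read-out.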

Compound 4, half-maximal cytotoxic concentration: 14000 nM
The estimate for compound 4 lay 1.1-fold (0.03 log units) above the measured number; measured number inside the range.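

In this assay, replacing benzyl with ethoxycarbonyl on an amide-type nitrogen gives a 3.4-fold higher number from compound 3 to compound 4 (0.53 log units; beyond the scatter), a modest shift toward lower toxicity in this test that lies beyond the usual scatter. Among the compounds shown here, this is the first readable step, as the only earlier step cannot be read, and it shows that the group on this nitrogen affects the read-out. Compound 4 also still gives a true number, so this change keeps the value measurable.

The compounds shown do not tell whether the step belongs to the carbonyl or to the loss of the aromatic ring, and an acetyl or a plain ethyl on the same nitrogen would help separate the two. Nor can the step be set against compound 1 or compound 2, each of which holds a limit and not a number: the limit of > 50000 nM in this assay, at which 2 of the 4 values shown sit.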